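Hydroxy entering beside bromo in the shared core

This account rests on a few compounds, and the source may have more. Where it says the series, first, only, none or still open, it means among the compounds named here.

Compound 1 `O=C(Nc1cccc(Cl)c1)c1cc(Br)cc(Br)c1O` gives 29000 nM in an assay for inhibition of HSP60/HSP10 (Homo sapiens), with a stated time of 60 min; on this read-out higher numbers stand for weaker inhibition and lower numbers for stronger inhibition.
Compound 2 `O=C(Nc1cccc(Cl)c1)c1ccccc1O` gives > 100000 nM in this assay, a limit.
Compound 3 `O=C(Nc1cccc(Cl)c1)c1cccc(Br)c1` gives > 100000 nM in this assay, a limit.

Compound 3 stands at the limit of this assay, as the limit of > 100000 nM in this assay, at which 2 of the 3 values shown sit, notes, so its own value is not a number. Compound 4 `O=C(Nc1cccc(Cl)c1)c1cccc(Br)c1O` differs from it by hydroxy in place of hydrogen on an aromatic carbon. No step between measured compounds is shown, so only the single values can be compared: compound 1, which carries both hydroxy and two bromo groups, gives a number, while compound 2, with hydroxy alone, sits at the limit. Compound 4, with hydroxy and one bromo group, is therefore expected to sit between those two, and the step from compound 3 to compound 4 is expected to be a modest gain, an at least 1.6-fold lower number from compound 3 to compound 4 (0.22 log units; that floor lies within the scatter), though it may not clear the limit. Compound 4 is estimated at 60000 nM, within a range from 25000 nM to 150000 nM.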

Compound 4, half-maximal inhibitory concentration: > 100000 nM
Compound 4 gave a limit, no number; the forecaster's own chance of this, stated with the estimate: 50%; middle value at least 1.6-fold (0.22 log units) from the limit.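

In this assay, hydroxy in place of hydrogen, ortho to a bromo group, does not by itself yield a number: compound 4 gives > 100000 nM, which is a limit. The steps to compound 4 from compound 3 and from compound 2 cannot be read, as both ends of each are limits. The one readable step, hydrogen in place of bromo on an aromatic carbon, is an at least 3.4-fold higher number from compound 1 to compound 4 (0.53 log units; beyond the scatter), so among the compounds shown a number appears only with the further bromo group of compound 1.

The compounds that stay at the limit cannot be ranked against one another: the limit of > 100000 nM in this assay, at which 3 of the 4 values shown sit. As far as these compounds go, what the hydroxy contributes in compound 1 stays open, as does whether a methoxy group or a carboxylic acid in its place would keep a number.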